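This account rests on a few compounds, and the source may have more. Where it says the series, first, only, none or still open, it means among the compounds named here.

Measured so far:
compound 1 `Cc1cc(O)cc(-c2nn(CC#N)cc2-c2ccnc(-c3ccc(Oc4ccccc4)cc3)c2)c1`: 5810 nM
compound 2 `COc1cc(C)cc(-c2nn(CC#N)cc2-c2ccnc(-c3ccc(N(C)C)cc3)c2)c1`: 17300 nM

Of the compounds shown here, two share a common core and have been tested in a functional assay on T47D cells (Homo sapiens) for inhibition, read by sulforhodamine B assay, with a stated time of 48 h; a higher number here means a weaker inhibitor of growth, a lower number a stronger inhibitor of growth. In this assay compound 1 gives 5810 nM, while compound 2 gives 17300 nM. Compound 2 thus stands at the highest of the two numbers, and the gap to compound 1 lies beyond the scatter, so compound 2 is the weaker growth inhibitor of the pair.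

The next compound, compound 3 `Cc1cc(O)cc(-c2nn(CC#N)cc2-c2ccnc(-c3ccc(N(C)C)cc3)c2)c1`, has not been measured. It differs from compound 2 in one place: hydrogen in place of methyl on an oxygen on an aromatic ring. Compound 1 also carries a hydroxy group on that ring, and in this assay compound 1 gives 5810 nM, a lower number than compound 2, but compound 1 differs from compound 2 in a second place as well, so that comparison cannot be credited to the hydroxy group alone. Among the compounds with values here, no single-change step from methoxy to hydroxy is available among the measured compounds.

Compound 3 is therefore expected to give roughly 9000 nM, with a range from 3000 nM to 27000 nM. That estimate means an expected step of a 1.9-fold lower number from compound 2 to compound 3 (0.28 log units; within the scatter), a modest move toward stronger inhibition, only just beyond the scatter.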

Compound 3, concentration for total growth inhibition: 12400 nM
Beside the measured number, compound 3's estimate is 1.4-fold (0.14 log units) below it; the measured number falls inside the stated range.
By their numbers in this assay, from the lowest: compound 1; then compounds 3 and 2 (each within the scatter of the next).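

In this assay, within the data shown here, hydrogen in place of methyl on the oxygen gives a 1.4-fold lower number from compound 2 to compound 3 (0.14 log units; within the scatter), the first single-change reading at this position, and it leaves methoxy and hydroxy indistinguishable while the dimethylamino group is present. Compound 3 also isolates the other varied place: dimethylamino in place of phenoxy on an aromatic carbon gives a 2.1-fold higher number from compound 1 to compound 3 (0.33 log units; beyond the scatter), a modest step and the only one of these two single changes that lies beyond the scatter. Nothing measured here offers an explanation for the size of either step.

From the compounds shown here alone, each step rests on a single pair of compounds, so it remains open whether methoxy and hydroxy would still read alike with phenoxy in place of dimethylamino. Also open, going by these compounds, is how this series would respond to an amine in place of the hydroxy group, a longer chain such as ethyl or propyl on the oxygen, or a carboxylic acid where the dimethylamino group sits.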